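Swapping Methoxymethyl for Chlorophenyl: Expected Cell Tolerance

This account rests on a few compounds, and the source may have more. Where it says the series, first, only, none or still open, it means among the compounds named here.

Measured so far:
Compound 1, `COc1cc(CNC(=O)c2nc(C(C)(C)NC(=O)OCc3ccccc3)nc(O)c2O)cc(OC)c1OC`, gives 110000 nM in an ADME assay on C8166 cells (Homo sapiens) for cytotoxicity, read by MTT assay, with a stated time of 3 days; a higher number here means that more compound is tolerated, a lower number that less compound is tolerated.
Compound 2, `COCCNC(=O)c1nc(C(C)(C)NC(=O)OCc2ccccc2)nc(O)c1O`, gives 348000 nM in this assay.
Compound 3, `CC(C)(NC(=O)OCc1ccccc1)c1nc(O)c2oc(=O)[nH]c2n1`, reaches only > 500000 nM in this assay, which is a limit of the measurement rather than a number.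

Of the two numbers measured in this assay, compound 2 stands highest. Among the measured compounds shown here, its nearest neighbour is compound 1, and the single step between them is a 3.2-fold higher number from compound 1 to compound 2 (0.50 log units; beyond the scatter). The remaining value is a limit (the limit of > 500000 nM in this assay, at which 1 of the 3 values shown sits), so it adds no number to compare against.

Compound 4, `CC(C)(NC(=O)OCc1ccccc1)c1nc(O)c(O)c(C(=O)NCc2ccccc2Cl)n1`, has not been measured yet. It differs from compound 2 in one place: 2-chlorophenyl in place of methoxymethyl on a saturated chain carbon bound to an amide-type nitrogen. For the measured compounds named here, the one measured step that bears on this change is a 3.2-fold higher number from compound 1 to compound 2 (0.50 log units; beyond the scatter), in which the methoxymethyl group entering for an aromatic ring raised the number. The change to compound 4 runs the other way: the methoxymethyl group leaves and an aromatic ring enters at the same place. A modest lowering of the number in this assay, of roughly the size seen before, is therefore expected.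

Compound 4 is expected to give about 130000 nM, with a likely range from 50000 nM to 350000 nM. This estimate corresponds to an expected step of a 2.7-fold lower number from compound 2 to compound 4 (0.43 log units; beyond the scatter).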

Compound 4, half-maximal cytotoxic concentration: 53900 nM
Compound 4: the middle estimate sits 2.4-fold (0.38 log units) above what was measured; measured number inside the range.
By their numbers in this assay, from the lowest: compound 4; then compound 1; then compound 2. At a limit, above all of these: compound 3.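

The lowering seen earlier with an aromatic ring at this place is not confined to 3,4,5-trimethoxyphenyl: a 6.5-fold lower number from compound 2 to compound 4 (0.81 log units; beyond the scatter) shows that 2-chlorophenyl on the same saturated chain carbon also means less compound is tolerated in this assay. The two aromatic groups do not give the same result either, since a 2.0-fold lower number from compound 1 to compound 4 (0.31 log units; beyond the scatter) is printed as lying beyond the usual scatter, so what the ring carries also appears to matter, and not just whether a ring is there. Among the three compounds that differ at this place, methoxymethyl therefore stands highest and both aromatic groups lie lower, and none of the three goes against that order.

Plain phenyl at this place would help separate the effect of the ring from that of its chlorine or its three methoxy groups, while 4-chlorophenyl would show whether the chlorine's place on the ring counts, and a dimethylaminomethyl group or a longer ether chain would test how far the higher number extends beyond methoxymethyl. The data shown offer no measurement that explains these differences in tolerance.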